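A few compounds are considered here, and "the series" means these few. Any claim that something is new, unique, unknown or untested is made for them only; others in the source may bear on it.

Measured compounds in a functional assay for antagonist activity at thromboxane A2 receptor (Rattus norvegicus); a lower number here means tighter binding, a higher number weaker binding:
compound 1 `O=C(O)CC/C=C\CO[C@@H]1C(OCc2ccc(-c3ccccc3)cc2)CC[C@@H]1N1CCCCC1`, 15.9 nM
compound 2 `NC(=O)Cc1ccccc1-c1ccc(COC2CC[C@H](N3CCCCCC3)[C@H]2OC/C=C\CCC(=O)O)cc1`, 158 nM
compound 3 `O=C(O)CC/C=C\CO[C@@H]1[C@@H](OCc2ccc(-c3ccccc3)cc2)CC[C@@H]1N1CCCCC1`, 1000 nM

Compound 2 stands second highest of the three numbers in this assay; compound 3 lies a step above it and compound 1 a step below it, both gaps beyond the scatter. Among the compounds with values here, the only pair that differs in one place is compound 1 against compound 3, a step of a 63-fold higher number from compound 1 to compound 3 (1.80 log units; beyond the scatter), and that pair differs solely in the fact that one of compounds 1 and 3 is drawn with a defined configuration and the other without, at the place where they differ. It says nothing about the aryl substituent on the benzyl ether.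

Compound 4 `CS(=O)(=O)Nc1cccc(-c2ccc(COC3CC[C@H](N4CCCCCC4)[C@H]3OC/C=C\CCC(=O)O)cc2)c1` carries the change (a group of 11 heavy atoms (7 carbon, 1 nitrogen, 2 oxygen, 1 sulfur; one six-membered aromatic ring of carbon only) in place of a group of 10 heavy atoms (8 carbon, 1 nitrogen, 1 oxygen; one six-membered aromatic ring of carbon only), on an aromatic carbon). Within the data shown here, no measured step touches this position, so there is nothing to anchor a direction. The expectation therefore rests on compound 2 alone: a number close to its value, with no change beyond the scatter predicted, and a broad range to cover an unmeasured shift either way. Compound 4 is expected at 158 nM, between 50 nM and 500 nM. This corresponds to an expected step of no change at the digits printed from compound 2 to compound 4 (within the scatter).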

Compound 4, dissociation constant: 50.1 nM
Estimate against measurement, compound 4: 3.2-fold (0.50 log units) above; the measured number falls inside the stated range.
By their numbers in this assay, from the lowest: compound 1; then compound 4; then compound 2; then compound 3.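

Within the data shown here, the aromatic carbon para to a large group is the first place where a change of substituent can be read, and in this assay placing 3-(methanesulfonamido)phenyl there gives a 3.2-fold lower number from compound 2 to compound 4 (0.50 log units; beyond the scatter). The position is therefore not indifferent to the group it carries, and this one exchange moves the number towards tighter binding, although that direction rests on a single pair. No evidence at hand bears on the reason for this step.

Open, as far as these compounds go, is whether the lower number belongs to the methanesulfonamido group itself or to its place on the phenyl ring, and how a carboxylic acid or a methoxy group would read there. Also open, from the compounds shown here alone, is how the step would read with a defined configuration at the saturated ring carbon carrying the benzyl ether, which is drawn without one in both compounds.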